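This account rests on a few compounds, and the source may have more. Where it says the series, first, only, none or still open, it means among the compounds named here.

Measured so far:
- compound 1, `COc1cc(-c2nnc(SCC(=O)Nc3ccccc3)n2N)cc(OC)c1OC`: 1730 nM
- compound 2, `COc1cc(-c2nnc(SCC(=O)NCc3ccc(C)cc3)n2N)cc(OC)c1OC`: > 100000 nM

In a functional assay on HCT-116 cells (Homo sapiens) for antiproliferative activity, read by MTT assay, with a stated time of 48 h (a higher number here means a weaker inhibitor, a lower number a stronger inhibitor), compound 1 gives 1730 nM. Compound 2 reaches only the limit of this assay, > 100000 nM, so for compound 2 no number is known, only a limit (the limit of > 100000 nM in this assay, at which 1 of the 2 values shown sits). Going by the values given here, the one measured step, an at least 57-fold higher number from compound 1 to compound 2 (1.76 log units; beyond the scatter), is therefore itself a lower bound on the loss.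

Compound 3, `COc1ccc(CNC(=O)CSc2nnc(-c3cc(OC)c(OC)c(OC)c3)n2N)cc1OC`, keeps the shared core and the amide-type nitrogen with its saturated chain carbon, and differs from compound 2 only in the ring on that carbon: 3,4-dimethoxyphenyl in place of 4-methylphenyl on a saturated chain carbon bound to an amide-type nitrogen. Among the compounds with values here, no measured step changes substituents on this ring while the chain carbon is kept; the step from compound 1 to compound 2 shows only that inserting the chain carbon before a plain ring costs a great deal. With the chain carbon retained, compound 3 is expected to stay weak, most likely again at or near the limit, so the expected step of an at least 1.1-fold lower number from compound 2 to compound 3 (0.04 log units; that floor lies within the scatter) is small or none beyond the scatter. The estimate for compound 3 in this assay is 90000 nM, within 20000 nM to 300000 nM.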

Compound 3, half-maximal inhibitory concentration: > 100000 nM
Compound 3: no number, only a limit; the forecaster's own chance of this, stated with the estimate: 60%; at least 1.1-fold (0.04 log units) between middle value and limit.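

In this assay compound 3 gives > 100000 nM, which is a limit and not a number, so a second benzyl group with a different ring substitution ends up at the same limit as compound 2: the limit of > 100000 nM in this assay, at which 2 of the 3 values shown sit.

Putting 3,4-dimethoxybenzyl in place of phenyl on the amide-type nitrogen gives an at least 57-fold higher number from compound 1 to compound 3 (1.76 log units; beyond the scatter), a lower bound on the loss, so the large drop is no longer tied to 4-methylbenzyl alone. With limits on both sides, the step between compound 2 and compound 3 cannot be read, and the two compounds cannot be put in order; all that can be said is that neither ring substitution brings a value into the measurable range of this assay.

On these data alone, it remains open whether any group on the ring of the benzyl unit could restore activity, and how far above the limit compound 2 and compound 3 really lie. As far as these compounds go, it also remains open how an amine or a carboxylic acid on that ring would behave, or whether a longer chain between the amide-type nitrogen and the ring would read differently from the single chain carbon.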